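A few compounds are considered here, and "the series" means these few. Any claim that something is new, unique, unknown or untested is made for them only; others in the source may bear on it.

Measured so far:
compound 1 `CCOC(=O)c1sc(-c2ccccc2)nc1N` — in an assay on HEK293 cells for inhibition of transient receptor potential cation channel subfamily M member 8 (Homo sapiens), read by FLIPR, with stated times of 5 min and 3 min (a lower number here means a stronger inhibitor, a higher number a weaker inhibitor), compound 1 gives > 100000 nM, which is a limit of the assay and not a number.
compound 2 `CCOC(=O)c1sc(-c2ccccc2)nc1CO` — in this assay compound 2 gives > 100000 nM, again a limit of the assay rather than a number.

Compound 2 therefore stands at the limit, with no measured value to place it; the limit of > 100000 nM in this assay, at which 2 of the 2 values shown sit, holds both values shown. Going by the values given here, the only measured step, a step that the two limits leave unreadable from compound 1 to compound 2, is unreadable because both ends are limits.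

Compound 3 `CCOC(=O)c1sc(-c2ccccc2)nc1OC` differs from compound 2 by methoxy in place of hydroxymethyl on an aromatic carbon. Among the compounds with values here, no measured step bears on a methoxy group at this position, so the expectation rests on the two limits alone. Since compound 2 sits at the limit, the step that the limit leaves unreadable from compound 2 to compound 3 is expected to be no more than the scatter, with the result most likely again a limit. Compound 3 is thus estimated at 150000 nM, within 30000 nM to 1000000 nM.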

Compound 3, half-maximal inhibitory concentration: > 100000 nM
Compound 3: no number, only a limit; the forecaster's own chance of this, stated with the estimate: 85%; the middle value lies beyond the limit too.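

No new step can be read among compound 1, compound 2 and compound 3, since each gives only a limit in this assay, not a number: the limit of > 100000 nM in this assay, at which 3 of the 3 values shown sit.

The compounds shown leave open whether amino, hydroxymethyl and methoxy differ at all in inhibition, and which change to the shared core would give a measurable value.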